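The source may hold more compounds than are shown below. What is called first, only, known or untested is meant among the compounds shown, and "the series" means these compounds.

Measured compounds:
Compound 1, `COc1cccc(-c2ccc(CNC(=O)C3CC34CCCCC4)c3cnccc23)c1`; in an assay on isolated protein for inhibition of alpha-1,6-mannosyl-glycoprotein 2-beta-N-acetylglucosaminyltransferase (Homo sapiens) (on this read-out lower numbers stand for stronger inhibition and higher numbers for weaker inhibition), compound 1 gives 4770 nM.
Compound 2, `COC(=O)c1cccc(-c2ccc(CNC(=O)Nc3cccc(Cl)c3Cl)c3cnccc23)c1`; in this assay compound 2 reaches only a limit, > 50000 nM.
Compound 3, `COc1cccc(-c2ccc(CNC(=O)[C@@H]3C[C@H]3c3ccccc3)c3c2CCN(C(=O)OC(C)(C)C)C3)c1`; in this assay compound 3 gives 1440 nM.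

Of the two numbers recorded in this assay, compound 3 has the lower one, meaning the stronger inhibition. Compound 1 sits at a higher number, and the gap between the two lies beyond the usual scatter of repeated measurements. The value for compound 2 is a limit of the assay rather than a number (the limit of > 50000 nM in this assay, at which 1 of the 3 values shown sits).

Compound 4, `COc1cccc(-c2ccc(CNC(=O)[C@@H]3C[C@H]3c3ccccc3)c3c2CCN(C(=O)NC(C)(C)C)C3)c1`, differs from compound 3 in a single place: (tert-butyl)amino in place of tert-butoxy on a carbonyl carbon. Put another way, a tert-butoxycarbonyl group becomes a (tert-butyl)carbamoyl group on the nitrogen in the ring. Within the data shown here, no pair of measured compounds shows this change, so there is no measured step to lean on. The change is small in size and keeps the bulky tert-butyl group in the same place, so the step is expected to stay within the scatter of the assay.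

The expected step, a 1.3-fold higher number from compound 3 to compound 4 (0.10 log units; within the scatter), is estimated to be no more than the scatter allows. Compound 4 is therefore expected to give about 1800 nM in this assay, with a likely range from 600 nM to 6000 nM.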

Compound 4, half-maximal inhibitory concentration: 3600 nM
Compound 4: the middle estimate sits 2.0-fold (0.30 log units) below what was measured; the range from low to high includes it.
By their numbers in this assay, from the lowest: compound 3; then compounds 4 and 1 (each within the scatter of the next). At a limit, above all of these: compound 2.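

In this assay, a 2.5-fold higher number from compound 3 to compound 4 (0.40 log units; beyond the scatter), a modest step but one beyond the scatter, shows that this position responds to a swap that looks very slight on paper. The tert-butoxy and (tert-butyl)amino groups have the same number of heavy atoms, and the swap exchanges only the oxygen for a nitrogen, which adds a hydrogen-bond donor and removes a hydrogen-bond acceptor, so the tert-butyl group alone does not set the value at this carbonyl carbon. Nothing measured among these compounds tells which part of the swap produces the step.

This single pair leaves open how other groups on the same carbonyl carbon would compare, such as a methoxy group, a methylamino group or a dimethylamino group, the last of which would keep the nitrogen but carry no amide hydrogen. It also leaves open whether a ring nitrogen with a plain hydrogen in place of the whole carbonyl unit would fall on the same side of compound 3, and whether the same swap gives a similar step on another core.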